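Swapping a Pyridinyl Hydrazone for a Bromophenyl Hydrazone

The compounds below may be only part of what the source reports. "The series", "measured", "known", "first", "only" and "open" are said of these compounds alone.

Compound 3 `CCCSc1nc(N/N=C/c2cccnc2)c2nnn(Cc3ccccc3)c2n1` gives 38100 nM in a functional assay on MGC-803 cells (Homo sapiens) for antiproliferative activity, read by MTT assay, with a stated time of 72 h (a lower number here means a stronger inhibitor, a higher number a weaker inhibitor), the lowest of the two numbers in hand. Compound 1 `CCCSc1nc(N/N=C(\C)c2ccc(OC)cc2)c2nnn(Cc3ccccc3)c2n1` gives 44300 nM in this assay, and the two numbers stand within the scatter of each other. Compound 2 `CCCSc1nc(N/N=C/c2ccc(C)cc2)c2nnn(Cc3ccccc3)c2n1` returns only a limit in this assay, > 64000 nM. That limit is recorded as the limit of > 64000 nM in this assay, at which 1 of the 3 values shown sits. Within the data shown here, the single measured step, an at least 1.6-fold lower number from compound 2 to compound 3 (0.22 log units; that floor lies within the scatter), rests on that limit, so its true size is open. Compound 4 `CCCSc1nc(N/N=C(\C)c2ccc(Br)cc2)c2nnn(Cc3ccccc3)c2n1` differs from compound 3 by a group of 10 heavy atoms (8 carbon, 1 nitrogen, 1 bromine; one six-membered aromatic ring of carbon only) in place of a group of 8 heavy atoms (6 carbon, 2 nitrogen; one six-membered aromatic ring with 1 hetero atom), on a nitrogen on an aromatic ring. Among the measured compounds shown here, no measured step covers this exchange; the one measured step runs the other way, from a carbon-only ring to a ring with one hetero atom, and compound 1, which also carries a carbon-only ring, gives 44300 nM. Compound 4 is therefore expected near 42000 nM, with a range of 20000 nM to 90000 nM. The expected step of a 1.1-fold higher number from compound 3 to compound 4 (0.04 log units; within the scatter) is estimated to lie within the scatter.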

Compound 4, half-maximal inhibitory concentration: 6020 nM
Compound 4: the middle estimate sits 7.0-fold (0.84 log units) above what was measured; measured number below the stated range.
By their numbers in this assay, from the lowest: compound 4; then compounds 3 and 1 (each within the scatter of the next). At a limit, above all of these: compound 2.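

In this assay the step of a 7.4-fold lower number from compound 1 to compound 4 (0.87 log units; beyond the scatter) shows that bromo in place of methoxy on an aromatic carbon, a change in one place, carries the number beyond the scatter, which no earlier measured step had shown. The exchange on the nitrogen on an aromatic ring also passes beyond the scatter in a 6.3-fold lower number from compound 3 to compound 4 (0.80 log units; beyond the scatter), so the ring of carbon only in compound 4 gives a clearly lower number than the pyridinyl group of compound 3, while compound 1, also with a ring of carbon only, does not. The step of an at least 10-fold lower number from compound 2 to compound 4 (1.02 log units; beyond the scatter) rests on a limit for compound 2, so its true size stays open: the limit of > 64000 nM in this assay, at which 1 of the 4 values shown sits.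

As far as these compounds go, whether chloro or a nitrile in place of the bromo would give a similar number remains open. The compounds shown also do not separate the part played by the bromo from that of the methyl on the carbon with a double bond to nitrogen in the step from compound 2.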